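A few compounds are considered here, and "the series" means these few. Any claim that something is new, unique, unknown or untested is made for them only; others in the source may bear on it.

For the measured compounds named here, compound 1 `CC(C)CCc1c(OCCCCCC(=O)NO)ccc2ccc(=O)oc12` is the only compound here with a plain number in a functional assay on PC-3 cells (Homo sapiens) for antiproliferative activity, read by sulforhodamine B assay, with a stated time of 48 h; a higher number here means a weaker inhibitor of growth, a lower number a stronger inhibitor of growth; in this assay compound 1 gives 740 nM. Compound 2 `CC(C)CCc1c(OCCCCCCC(=O)NO)ccc2c1OC(=O)CC2` is reported in this assay only as a limit of the assay, > 30000 nM, which is the limit of > 30000 nM in this assay, at which 1 of the 2 values shown sits. Compound 3 `CC(C)CCc1c(OCCCCCCCC(=O)NO)ccc2ccc(=O)oc12` has not yet been measured in this assay. Compound 3 differs from compound 1 by 2-(hydroxycarbamoyl)ethyl in place of hydroxycarbamoyl on a saturated chain carbon, five bonds along the chain from an oxygen on an aromatic ring. Going by the values given here, no step between two measured compounds is available, so the expectation rests on the structural change alone. A modest weakening is expected, a 1.6-fold higher number from compound 1 to compound 3 (0.21 log units; within the scatter), though it may well lie within the scatter. For compound 3 the estimate in this assay is 1200 nM, with a range from 300 nM to 5000 nM.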

Compound 3, concentration for 50% growth inhibition: 1730 nM
For compound 3 the middle estimate is 1.4-fold (0.16 log units) below the measured one, within the range that was stated.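

Moving the hydroxycarbamoyl end further out along the chain, as 2-(hydroxycarbamoyl)ethyl in place of hydroxycarbamoyl, gives in this assay a 2.3-fold higher number from compound 1 to compound 3 (0.37 log units; beyond the scatter). So this position responds to chain length, but the change is modest and compound 3 still gives a plain number. Nothing measured here bears on the reason for this step.

As far as these compounds go, whether a still longer chain would continue this trend remains open, and so does the effect of a carboxylic acid or an amine in place of the hydroxycarbamoyl end.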